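The source may hold more compounds than are shown below. What is called first, only, known or untested is meant among the compounds shown, and "the series" means these compounds.

In an ADME assay on L02 cells (Homo sapiens) for cytotoxicity, read by MTT assay, with a stated time of 72 h (a higher number here means a weaker inhibitor, a lower number a stronger inhibitor), two compounds have been measured so far. Compound 1 `CC/C=C/C(=O)Nc1cccc(Oc2nc(Nc3ccn(C)n3)nc3c2CSCC3)c1`, which already carries but-1-en-1-yl on its carbonyl carbon, gives > 50000 nM, a limit of the assay and not a number. Compound 2 `C=CC(=O)Nc1cccc(Oc2nc(Nc3ccc(OC)cc3)nc3c2CSCC3)c1`, which carries vinyl there, gives > 50000 nM, also a limit and not a number. Compound 2 therefore has no exact value, and it shares its position with compound 1: the limit of > 50000 nM in this assay, at which 2 of the 2 values shown sit.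

Compound 3 `CC/C=C/C(=O)Nc1cccc(Oc2nc(Nc3ccc(OC)cc3)nc3c2CSCC3)c1` keeps the rest of compound 2 and has but-1-en-1-yl in place of vinyl on a carbonyl carbon whose other neighbours are an amide-type nitrogen: but-1-en-1-yl in place of vinyl on a carbonyl carbon. Going by the values given here, no measured pair shows this change alone, so the expectation rests on these two limits. The expected step of a number no higher from compound 2 to compound 3 (the limit leaves the size open) is none beyond the scatter in this assay. For compound 3 the estimated value is 50000 nM, with an expected range from 30000 nM to 100000 nM.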

Compound 3, half-maximal inhibitory concentration: > 50000 nM
Compound 3: a limit, no number; the forecaster's own chance of this, stated with the estimate: 85%; the middle value lies on the limit itself.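

No step can be read from compound 1 or compound 2 to compound 3, because all three values are limits of the assay and not numbers: the limit of > 50000 nM in this assay, at which 3 of the 3 values shown sit.

The compounds shown leave open whether but-1-en-1-yl in place of vinyl, or 4-methoxyphenyl in place of 1-methyl-1H-pyrazol-3-yl, changes the value at all.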